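The compounds below may be only part of what the source reports. "The series", "measured", "known", "first", "only" and "open" are said of these compounds alone.

Measured so far in a functional assay on Vero cells (Chlorocebus sabaeus) for cytotoxicity; on this read-out higher numbers stand for lower toxicity in this test and lower numbers for higher toxicity in this test

- Compound 1 `O=c1[nH]c(=O)n([C@@H]2CO[C@@H](CO)O2)cc1/C=C/Br` gives 100 ug/mL
- Compound 2 `O=c1[nH]c(=O)n([C@@H]2CO[C@@H](CO)S2)cc1/C=C/Br` gives 30 ug/mL

Of these two, compound 2 has the lower number, at 30 ug/mL, so it is the more toxic to the cells in this assay. Compound 1 stands higher at 100 ug/mL, and this gap lies beyond the usual scatter.

The next compound to be tested is compound 3 `O=c1[nH]c(=O)n([C@H]2CO[C@H](CO)S2)cc1/C=C/Br`. The change from compound 2 is the two compounds have the same atoms and bonds and differ only in configuration as drawn: 2 of 3 stereo elements differ; a stereocentre at a saturated ring carbon is drawn S in compound 2 and R in compound 3; a stereocentre at a saturated ring carbon is drawn R in compound 2 and S in compound 3. No atom or bond leaves or enters, so the comparison concerns only the configuration as drawn. Neither measured compound shows what such a change does to this read-out, so the data give no direction for it. The estimate therefore starts from compound 2 at 30 ug/mL, with only a slight lean towards higher numbers and wide margins on both sides. The expected change is a 1.3-fold higher number from compound 2 to compound 3 (0.12 log units; within the scatter), which would stay within the usual scatter. For compound 3 the estimated value is 40 ug/mL, with an expected range from 15 ug/mL to 100 ug/mL.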

Compound 3, half-maximal cytotoxic concentration: 100 ug/mL
Estimate against measurement, compound 3: 2.5-fold (0.40 log units) below; measured number inside the range.
By their numbers in this assay, from the lowest: compound 2; then compounds 1 and 3 (each within the scatter of the next).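

In this assay, inverting both stereocentres at the saturated ring carbons gives a 3.3-fold higher number from compound 2 to compound 3 (0.52 log units; beyond the scatter), which means lower toxicity to the cells in this test. Within the data shown here, compound 1 and compound 2 could not show this, as they share no step that isolates configuration; this pair shows that the three-dimensional arrangement at these two ring carbons can, by itself, move this read-out beyond the usual scatter. The shift can be assigned to configuration and not to any change of group because no atom or bond leaves or enters: the fact that compounds 2 and 3 differ only in the configuration as drawn

As far as these compounds go, both stereocentres change together in this pair, so it remains open whether one of them carries the step or both are needed. From the compounds shown here alone, it is also open whether configuration would matter in the same direction and to a similar extent with another group on the shared core, such as an amine in place of the hydroxyl of the hydroxymethyl group.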